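Replacing the Acetyl Group on the Ring Nitrogen

The compounds below may be only part of what the source reports. "The series", "measured", "known", "first", "only" and "open" are said of these compounds alone.

Measured so far:
compound 1 `COc1cc(C2=NN(C(=S)Nc3ccccc3)C(c3ccccc3)C2)ccc1O` — 550 nM in an assay on isolated protein for inhibition of Amine oxidase [flavin-containing] A (Homo sapiens), read by Amplex Red, with a stated time of 15 min; a higher number here means a weaker inhibitor, a lower number a stronger inhibitor
compound 2 `COc1cc(C2=NN(C(C)=O)C(c3ccccc3)C2)ccc1O` — 3870 nM in this assay

Among the compounds with values here, compound 2 stands at the higher of the two numbers; the single measured step, a 7.0-fold higher number from compound 1 to compound 2 (0.85 log units; beyond the scatter), leads to it. Compound 3 `COc1cc(C2=NN(C(=N)N)C(c3ccccc3)C2)ccc1O` differs from compound 2 by a group of 3 heavy atoms (1 carbon, 2 nitrogen; no ring) in place of a group of 3 heavy atoms (2 carbon, 1 oxygen; no ring), on an amine nitrogen in a ring. That step compared the acetyl group with a much larger group, so nothing measured tells how the new group behaves. Without a precedent, a step for a 1.3-fold lower number from compound 2 to compound 3 (0.11 log units; within the scatter) no larger than the scatter is expected. Compound 3 is estimated at 3000 nM, within 1000 nM to 9000 nM.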

Compound 3, inhibition constant: 9550 nM
Compound 3: the middle estimate sits 3.2-fold (0.50 log units) below what was measured; measured number outside the range, above it.
By their numbers in this assay, from the lowest: compound 1; then compound 2; then compound 3.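

Putting this group, with its 2 hydrogen-bond donors, in place of acetyl keeps the count of 3 heavy atoms yet gives a 2.5-fold higher number from compound 2 to compound 3 (0.39 log units; beyond the scatter), so on this amine nitrogen in a ring the number can shift beyond the scatter without any change in heavy-atom count. The large group of compound 1 now stands further ahead, with a 17-fold higher number from compound 1 to compound 3 (1.24 log units; beyond the scatter). No available evidence bears on why the number rises. Still open, going by these compounds, is whether the sulfur or the aromatic ring of that large group goes with its lower number. On these data alone, how a benzoyl group or a longer alkyl chain would fare on this nitrogen also stays unknown.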